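Methyl to chloro on the shared core: expected outcome

The compounds below may be only part of what the source reports. "The series", "measured", "known", "first", "only" and "open" are said of these compounds alone.

Compound 1 `Oc1ccccc1NC(=S)Nc1ccc2[nH]ccc2c1` and compound 2 `Cc1ccc(NC(=S)Nc2ccc3[nH]ccc3c2)c(O)c1` carry the same core and differ by methyl in place of hydrogen on an aromatic carbon. In an ADME assay on isolated protein for inhibition of peroxidase (Raphanus sativus), read by fluorescence and Amplex Red, tested at 5 uM (on this read-out lower numbers stand for a stronger effect and higher numbers for a weaker effect at the one concentration tested), compound 1 gives 43.9% and compound 2 gives 47.3%. The step of a number 3.4 percentage points higher from compound 1 to compound 2 (within the scatter) is within the scatter, so the two read as one number. Among the compounds with values here, of the two values recorded, compound 2 stands at one end, but its only neighbour, compound 1, lies within the scatter of it, and no order follows.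

Compound 3 `Oc1cc(Cl)ccc1NC(=S)Nc1ccc2[nH]ccc2c1` differs from compound 2 by chloro in place of methyl on an aromatic carbon. Within the data shown here, the sole measured step, a number 3.4 percentage points higher from compound 1 to compound 2 (within the scatter), bears on this only loosely: it also alters a group on an aromatic carbon of the core, and it moved nothing beyond the scatter. Among the measured compounds shown here, no measured step exchanges a methyl for a chloro, so the size of the effect of chloro is unknown here. For the measured compounds named here, with the only evidence being the flat step from compound 1 to compound 2, the step of a number 0.3 percentage points lower from compound 2 to compound 3 (within the scatter) is expected to stay within the scatter. Compound 3 is therefore estimated at 47% in this assay, with a range from 32% to 62%.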

Compound 3, a percentage reported as activity, at one concentration (the size of the read-out at that concentration, not a potency): 58.9%
Beside the measured number, compound 3's estimate is 11.9 percentage points below it, within the range that was stated.
By their numbers in this assay, from the lowest: compounds 1 and 2 (each within the scatter of the next); then compound 3.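

In this assay, the place on the six-membered aromatic ring that is meta to a hydroxy group and para to a large group proves sensitive to the group it carries: chloro in place of hydrogen gives a number 15 percentage points higher from compound 1 to compound 3 (beyond the scatter) and chloro in place of methyl gives a number 11.6 percentage points higher from compound 2 to compound 3 (beyond the scatter) in the same direction. Hydrogen and methyl at this place read as one number, whereas chloro stands apart from both, so compound 3 shows the weakest effect of the three at the one concentration tested, though both steps are modest in size. Nothing on hand accounts for chloro parting from methyl here, although the two groups match in heavy-atom count and neither adds a hydrogen-bond donor or acceptor.

The three compounds leave open whether the weaker effect belongs to chloro alone or extends to other groups at this place, such as fluoro, bromo, methoxy, an amine or a carboxylic acid. They also leave open whether chloro would give a step of similar size at another place on the same ring or at other concentrations.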